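Swapping 2-Cyanophenyl for 4-Chlorophenyl on the Sulfonyl Sulfur

A few compounds are considered here, and "the series" means these few. Any claim that something is new, unique, unknown or untested is made for them only; others in the source may bear on it.

Among the measured compounds shown here, in an ADME assay on the whole organism (Rattus norvegicus, strain Sprague-Dawley) for pharmacokinetics, read by LC-MS, with a stated time of 30 min (a higher number here means that more of the compound sits outside the plasma, a lower number that more of the compound stays in the plasma), compound 3 (`N#Cc1ccc(O[C@H]2CN(S(=O)(=O)c3ccccc3C#N)C[C@@]2(O)CO)cc1F`) gives 4.6 L/kg, the lowest of the three numbers measured so far. Compound 2 (`N#Cc1ccc(O[C@H]2CN(S(=O)(=O)c3ccc(C(F)(F)F)cc3C#N)C[C@@]2(O)CO)cc1F`) stands at 73 L/kg, and compound 1 (`N#Cc1ccc(O[C@H]2CN(S(=O)(=O)c3ccc(C(F)(F)F)cc3)C[C@@]2(O)CO)cc1F`) stands at 180 L/kg. The next compound, compound 4 (`N#Cc1ccc(O[C@H]2CN(S(=O)(=O)c3ccc(Cl)cc3)C[C@@]2(O)CO)cc1F`), differs from compound 3 as follows: 4-chlorophenyl in place of 2-cyanophenyl on a sulfonyl sulfur. In words, this is 4-chlorophenyl in place of 2-cyanophenyl on a sulfonyl sulfur.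

For the measured compounds named here, the nearest precedent is a change of the same group, which gave a 39-fold lower number from compound 1 to compound 3 (1.59 log units; beyond the scatter), large and beyond the scatter. Two smaller changes also bear on it. Removing trifluoromethyl gave a 16-fold lower number from compound 2 to compound 3 (1.20 log units; beyond the scatter), also large, while adding cyano to an aromatic carbon gave a 2.5-fold lower number from compound 1 to compound 2 (0.39 log units; beyond the scatter), a modest step. Among these three compounds, the two carrying trifluoromethyl show the higher numbers, and none goes against this. Going by the values given here, no measured compound carries 4-chlorophenyl, however, so the data do not show how much of that large step returns with this group.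

A large rise is therefore expected, estimated as an 11-fold higher number from compound 3 to compound 4 (1.04 log units; beyond the scatter), short of the full size of the precedent. Compound 4 is estimated at 50 L/kg, with an expected range of 12 L/kg to 180 L/kg.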

Compound 4, volume of distribution at steady state: 170 L/kg
Compound 4: middle estimate off by 3.4-fold (0.53 log units), on the low side; the range from low to high includes it.
By their numbers in this assay, from the lowest: compound 3; then compound 2; then compounds 4 and 1 (each within the scatter of the next).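

At the sulfonyl sulfur, a 37-fold higher number from compound 3 to compound 4 (1.57 log units; beyond the scatter) in this assay shows that the group on this position can carry the number back up without any trifluoromethyl, so compound 4 goes against the earlier pattern in which only the two trifluoromethyl compounds stood high. Chloro in place of trifluoromethyl on the aromatic carbon gives a 1.1-fold lower number from compound 1 to compound 4 (0.02 log units; within the scatter), so for this read-out the two groups cannot be told apart in this series, and the high number of compound 1 is not specific to trifluoromethyl. Nothing measured on these groups speaks to why the number moves this far at this position, and the step stands here as an observation only.

The compounds shown leave open whether plain phenyl on the sulfonyl sulfur would stand with compound 4 or with compound 3, which would tell whether the high number needs a chlorine or trifluoromethyl at all or only the absence of the nitrile. They also leave open whether a 4-methoxyphenyl or a phenyl ring bearing a carboxylic acid or an amine would bring the number down as far as compound 3 does.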